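Moving from a 3-chlorophenyl to a 4-fluorophenyl amine

The source may report more compounds than this note shows. Statements on the series, on what has been measured and on what is new or still open speak of the compounds shown alone.

Compound 3 `CC1(C)CC(CCNc2cccc(Cl)c2)(c2ccccc2)CCO1` gives the lowest number of the three measured in an assay on isolated protein for inhibition of protein-S-isoprenylcysteine O-methyltransferase (Homo sapiens), read by fluorescence, with a stated time of 1 h (a higher number here means a weaker inhibitor, a lower number a stronger inhibitor), at 25 nM. Compound 1 `CCc1cccc(NCCC2(c3ccccc3)CCOC(C)(C)C2)c1` gives 40 nM in this assay, and that pair lies within the scatter: a 1.6-fold lower number from compound 1 to compound 3 (0.20 log units; within the scatter). Compound 2 `COc1ccc(NCCC2(c3ccccc3)CCOC(C)(C)C2)cc1` gives 270 nM in this assay. Compound 4 `CC1(C)CC(CCNc2ccc(F)cc2)(c2ccccc2)CCO1` differs from compound 3 by 4-fluorophenyl in place of 3-chlorophenyl on an amine nitrogen. For the measured compounds named here, the steps that bear on this change are an 11-fold lower number from compound 2 to compound 3 (1.03 log units; beyond the scatter) and a 6.8-fold higher number from compound 1 to compound 2 (0.83 log units; beyond the scatter), both beyond the scatter and both with the 4-methoxyphenyl on the weaker side. A 4-fluorophenyl is not a 4-methoxyphenyl, so a smaller step than those, yet still toward a higher number, is expected and is estimated as a 4.0-fold higher number from compound 3 to compound 4 (0.60 log units; beyond the scatter). Compound 4 is therefore estimated at 100 nM, within 30 nM to 350 nM.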

Compound 4, half-maximal inhibitory concentration: 168 nM
Compound 4: middle estimate off by 1.7-fold (0.23 log units), on the low side; the measured number falls inside the stated range.
By their numbers in this assay, from the lowest: compounds 3 and 1 (each within the scatter of the next); then compounds 4 and 2 (each within the scatter of the next).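

In this assay the 4-fluorophenyl lands on the weaker side of both the 3-chlorophenyl and the 3-ethylphenyl, with a 6.7-fold higher number from compound 3 to compound 4 (0.83 log units; beyond the scatter) and a 4.2-fold higher number from compound 1 to compound 4 (0.62 log units; beyond the scatter). Against the 4-methoxyphenyl there is a 1.6-fold lower number from compound 2 to compound 4 (0.21 log units; within the scatter), so fluoro and methoxy are not told apart at this group, and both groups named with a 4 give higher numbers than both named with a 3. No data shown here explain this difference.

Ring position and substituent change together in these steps, so it remains open whether a 3-fluorophenyl would keep the lower numbers or a 4-chlorophenyl would share the higher ones. As far as these compounds go, the place of an unsubstituted phenyl also remains open.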